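The source may hold more compounds than are shown below. What is called first, only, known or untested is meant among the compounds shown, and "the series" means these compounds.

Measured so far:

Compound 1, `COc1ncnc(Nc2ccc(Cl)c(OCC=C(C)C)c2)n1`, gives 18000 nM in an ADME assay on MT2 cells (Homo sapiens) for cytotoxicity; on this read-out lower numbers stand for higher toxicity in this test and higher numbers for lower toxicity in this test.
Compound 2, `CC(C)=CCOc1cc(Nc2ncnc(N)n2)ccc1Cl`, gives 48000 nM in this assay.
Compound 3, `COc1ccnc(Nc2ccc(C#N)c(OCC=C(C)C)c2)n1`, gives 230 nM in this assay.

Compound 3 has the lowest number of the three, and both of its gaps to the others are beyond the scatter. The difference between the core of compound 3 and the core of compound 1 is not broken down here.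

From compound 1 to compound 2 one change is made: amino in place of methoxy on an aromatic carbon. In this assay this gave a 2.7-fold higher number from compound 1 to compound 2 (0.43 log units; beyond the scatter).

Compound 4, `CC(C)=CCOc1cc(Nc2nccc(N)n2)ccc1C#N`, has not yet been measured. From compound 3 to compound 4 the change is amino in place of methoxy on an aromatic carbon. This is the same kind of change as from compound 1 to compound 2, but not the same: in compound 1 the place is on a six-membered aromatic ring with 3 nitrogen, between two ring nitrogen atoms, whereas in compound 3 it is on a six-membered aromatic ring with 2 nitrogen, next to the ring nitrogen.

Because the earlier step of a 2.7-fold higher number from compound 1 to compound 2 (0.43 log units; beyond the scatter) was modest, a step of similar direction and size is expected here, namely a 2.4-fold higher number from compound 3 to compound 4 (0.38 log units; beyond the scatter). In this assay compound 4 is therefore estimated at 550 nM, expected to fall between 170 nM and 1800 nM.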

Compound 4, half-maximal cytotoxic concentration: 41 nM
For compound 4 the middle estimate is 13-fold (1.13 log units) above the measured one, outside the stated range (below it).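

In this assay amino in place of methoxy on an aromatic carbon lowered the number on the core of compound 3 (a 5.6-fold lower number from compound 3 to compound 4 (0.75 log units; beyond the scatter)), so the rise seen on the core of compound 1 did not carry over. The two steps do not agree, which shows that the result of this change in this series depends on the core that carries it: the same change on two cores in this assay, a 2.7-fold higher number (0.43 log units; beyond the scatter) from compound 1 to compound 2 and a 5.6-fold lower number (0.75 log units; beyond the scatter) from compound 3 to compound 4, 15-fold (1.17 log units) apart, beyond the scatter of two such steps

What this does not show is which difference between the two cores decides the direction, as they differ in more than one place, and with a single pair on each core no rule for a further core follows.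

The compounds shown leave open whether a methylamino or dimethylamino group in the same place would follow amino on either core. They also leave open whether the swap would behave alike with an ethoxy group in place of the longer ether chain on the core of compound 3.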